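The compounds below may be only part of what the source reports. "The series", "measured", "known", "first", "only" and "open" are said of these compounds alone.

Compound 1 `O=C(CCCCC1CCSS1)Nc1ccc(Br)cn1` and compound 3 `O=C(CCCCC(S)CCS)Nc1ccc(Br)cn1` share one core. In a functional assay on NCI-H460 cells (Homo sapiens) for inhibition, read by MTT assay, with a stated time of 24 h, tested at 100 ug/mL (on this read-out higher numbers stand for more inhibition of growth at the one concentration tested and lower numbers for less inhibition of growth), compound 1 gives 52%, and compound 3 gives 55.9%. The change between them, (a group of 5 heavy atoms (3 carbon, 2 sulfur; no ring) in place of a group of 5 heavy atoms (3 carbon, 2 sulfur; one five-membered non-aromatic ring with 2 hetero atoms), on a saturated chain carbon, four bonds along the chain from a carbonyl carbon), makes a step of a number 3.9 percentage points higher from compound 1 to compound 3 (within the scatter). Compound 2 `O=C(CCCCC1CCSS1)Nc1cccc2ccccc12` carries a different core; how its core differs from that of compound 1 is not broken down here. In this assay compound 2 is reported as "not active" (no number reported), without a number. Compound 4 `O=C(CCCCC(S)CCS)Nc1cccc2ccccc12` has not yet been measured; it arises from compound 2 by the same change, (a group of 5 heavy atoms (3 carbon, 2 sulfur; no ring) in place of a group of 5 heavy atoms (3 carbon, 2 sulfur; one five-membered non-aromatic ring with 2 hetero atoms), on a saturated chain carbon, four bonds along the chain from a carbonyl carbon). Because that change gave only a number 3.9 percentage points higher from compound 1 to compound 3 (within the scatter), compound 4 is expected to stay close to compound 2 and to show little growth inhibition. Compound 4 is therefore estimated at 10%, between 0% and 30%, and it may again be reported without a number.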

Compound 4, percent growth inhibition at one concentration: 2.18%
Compound 4: the middle estimate sits 7.8 percentage points above what was measured; measured number inside the range.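

Among these compounds, compound 2 has no reported number, so no step from compound 2 to compound 4 can be read. The compounds shown leave open whether swapping the ring for 1,3-disulfanylpropyl changes growth inhibition on the core of compound 2. No supporting evidence bears on this result.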